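The compounds below may be only part of what the source reports. "The series", "measured", "known", "first", "only" and "open" are said of these compounds alone.

Compound 1 `COc1cc(-c2nn(-c3cccc(NC(=O)c4ccc(Cl)c(C(F)(F)F)c4)c3)cc2-c2ccncc2)ccc1Cl` and compound 2 `COc1cc(-c2nn(-c3cccc(NC(=O)Nc4ccc(Cl)c(C(F)(F)F)c4)c3)cc2-c2ccncc2)ccc1Cl` share one core and differ only in the linkage to the (4-chloro-3-(trifluoromethyl)phenyl) group. In a functional assay on MDA-MB-435 cells (Homo sapiens) for inhibition, read by sulforhodamine B assay, with a stated time of 48 h (on this read-out lower numbers stand for stronger inhibition of growth and higher numbers for weaker inhibition of growth), compound 1 gives 664 nM, and compound 2 gives 683 nM; the step of a 1.0-fold higher number from compound 1 to compound 2 (0.01 log units; within the scatter) lies within the scatter, so compound 2 stands level with compound 1 on the numbers known, its value simply the higher of the two. Compound 3 `COc1cc(-c2nn(-c3cccc(NC(=O)c4ccccc4)c3)cc2-c2ccncc2)ccc1Cl` carries the change (phenyl in place of (4-chloro-3-(trifluoromethyl)phenyl)amino on a carbonyl carbon). Going by the values given here, the one measured step bears on it only in part, since that step exchanged the linkage while keeping the substituted ring, whereas here the substituted ring and its nitrogen go together and a bare phenyl remains. The data give no direct comparison for such a loss. For compound 3 in this assay a weaker result is expected, a step of a 4.4-fold higher number from compound 2 to compound 3 (0.64 log units; beyond the scatter), giving an estimate of 3000 nM with a range from 800 nM to 15000 nM.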

Compound 3, concentration for 50% growth inhibition: 189 nM
The estimate for compound 3 lay 16-fold (1.20 log units) above the measured number; the measured number lies below the stated range.
By their numbers in this assay, from the lowest: compound 3; then compounds 1 and 2 (each within the scatter of the next).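

In this assay, the change on the carbonyl carbon does matter once the substituted ring itself is given up: replacing the urea's (4-chloro-3-(trifluoromethyl)phenyl)amino with phenyl gives a 3.6-fold lower number from compound 2 to compound 3 (0.56 log units; beyond the scatter), and replacing the amide's 4-chloro-3-(trifluoromethyl)phenyl with phenyl gives a 3.5-fold lower number from compound 1 to compound 3 (0.55 log units; beyond the scatter). Going by these compounds alone, the earlier pair showed only that the linkage could change without a shift in the number, whereas these steps show that the chloro and trifluoromethyl substituents are not needed for growth inhibition at this position and that the bare phenyl amide is the better of the three. No evidence is at hand that accounts for this gain. The compounds shown leave open whether the chlorine or the trifluoromethyl alone carries the loss, as a 4-chlorophenyl or a 3-(trifluoromethyl)phenyl group would test. They also leave open how an unsubstituted phenylamino group or a small methyl group would fare on the same carbonyl carbon.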